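Fluoro for Methoxy: Does Permeability Move?

The compounds below may be only part of what the source reports. "The series", "measured", "known", "first", "only" and "open" are said of these compounds alone.

Measured in an ADME assay for permeability, using PAMPA, with a stated time of 30 min, at pH 7.4; a lower number here means that the compound crosses the layer more slowly, a higher number that the compound crosses the layer faster:
compound 1 `COc1ccc(-c2ccc3c(NCCCNCc4cccc(OC)c4O)ccnc3c2)cc1` gives 237 10^-6 cm/s
compound 2 `COc1cccc(CNCCCNc2ccnc3cc(-c4ccc(F)cc4)ccc23)c1O` gives 237 10^-6 cm/s
compound 3 `COc1ccc(Oc2ccc3c(NCCCNCc4cc(F)ccc4OC)ccnc3c2)cc1` gives 317 10^-6 cm/s

Compound 2 differs from compound 1 by a single change, (fluoro in place of methoxy on an aromatic carbon), and the step it made is no change at the digits printed from compound 1 to compound 2 (within the scatter). The cores of compound 1 and compound 3 differ in more than one place, and that difference is not broken down here. Compound 4 `COc1ccc(F)cc1CNCCCNc1ccnc2cc(Oc3ccc(F)cc3)ccc12` is not yet measured; it differs from compound 3 by fluoro in place of methoxy on an aromatic carbon, the same change at a place described in the same words. Because the step already seen is no change at the digits printed from compound 1 to compound 2 (within the scatter), a step of about that size is expected for compound 4: no change at the digits printed from compound 3 to compound 4 (within the scatter). Compound 4 is therefore estimated at 317 10^-6 cm/s, expected to lie between 200 10^-6 cm/s and 500 10^-6 cm/s.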

Compound 4, apparent permeability: 317 10^-6 cm/s
Estimate against measurement, compound 4: no gap at the digits printed; low and high end bracket the measured number.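

In this assay, fluoro in place of methoxy gives no change at the digits printed from compound 3 to compound 4 (within the scatter). Set beside the earlier step, the same change behaves alike on the two cores: the same change on two cores in this assay, no change at the digits printed (within the scatter) from compound 1 to compound 2 and no change at the digits printed (within the scatter) from compound 3 to compound 4, 1.0-fold (0.00 log units) apart, within the scatter of two such steps

For these two pairs, then, the change carries from one core to the other, but two pairs make no rule for the whole series, and the numbers do not say why the values stay level.

The compounds shown leave open whether the same holds on a third core. They also leave open what an amine, a carboxylic acid or a longer chain in place of the fluoro would do in this assay.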